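The source may report more compounds than this note shows. Statements on the series, on what has been measured and on what is new or still open speak of the compounds shown alone.

In a functional assay on KB cells (Homo sapiens) for inhibition, read by MTT assay, with a stated time of 24 h, tested at 10 ug/mL (a lower number here means less inhibition of growth, a higher number more inhibition of growth at the concentration tested), compound 1 `O=C(CCCCC(S)CCS)NO` gives 41.5% and compound 2 `O=C(CCCCC(S)CCS)Nc1ccccc1` gives 8.62% as the lower of the two numbers. Compound 3 `O=C(CCCCC(S)CCS)Nc1cccc(C(F)(F)F)c1` differs from compound 2 by trifluoromethyl in place of hydrogen on an aromatic carbon in the form of trifluoromethyl in place of hydrogen on an aromatic carbon. For the measured compounds named here, the one measured step of a number 32.9 percentage points lower from compound 1 to compound 2 (beyond the scatter) is large but lies at another place, phenyl in place of hydroxy on an amide-type nitrogen, so it sets no size for this change. In this assay the expected a number 4.4 percentage points higher from compound 2 to compound 3 (within the scatter) is a slight rise, not beyond the scatter. Compound 3 is estimated at 13% within a range from 3% to 28% for this measurement.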

Compound 3, percent growth inhibition at one concentration: 1.97%
The estimate for compound 3 lay 11 percentage points above the measured number; measured number outside the range, below it.
By their numbers in this assay, from the lowest: compounds 3 and 2 (each within the scatter of the next); then compound 1.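

In this assay trifluoromethyl in place of hydrogen on an aromatic carbon gives a number 6.7 percentage points lower from compound 2 to compound 3 (within the scatter) and so does not separate from hydrogen at this place, meta to a large group. The step shows that adding these 4 heavy atoms to the phenyl of compound 2 produces no change beyond the scatter. No measured evidence on this result is available to explain it. From the compounds shown here alone, whether an amine or a carboxylic acid at this same place would move the number beyond the scatter remains open.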